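The source may report more compounds than this note shows. Statements on the series, on what has been measured and on what is new or still open speak of the compounds shown alone.

Compound 1 `Cc1ccc(-c2ccccc2NCC2=NCCN2)n1C` gives 0% in a functional assay with Alpha-1D adrenergic receptor (Homo sapiens) as the target, read by calcium flux; a higher number here means a larger maximal response, a lower number a smaller maximal response. Compound 2 `CC(C)n1nccc1-c1ccccc1NCC1=NCCN1` gives 0%.

Compound 2 thus stands level with compound 1 at the digits shown, the two values lying within the usual scatter of one another. Compound 3 `Cn1nccc1-c1ccccc1NCC1=NCCN1` has not yet been measured in this assay. It differs from compound 2 at one place: methyl in place of isopropyl on an aromatic nitrogen. Going by the values given here, no measured pair here shows what such a change does, so the expected step from compound 2 to compound 3 is estimated as none beyond the scatter, no change at the digits printed from compound 2 to compound 3 (within the scatter). Compound 3 is therefore expected to give 0%, with a range from 0% to 10%.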

Compound 3, largest response reached (reported as maximal response), in percent of the reference or control that the assay uses: 0%
Compound 3: the middle estimate sits on the measured number at the digits printed; measured number inside the range.
By their numbers in this assay, from the lowest: compounds 1, 2 and 3 (each within the scatter of the next).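

Going by these compounds alone, replacing isopropyl with methyl on the aromatic nitrogen gives no change at the digits printed from compound 2 to compound 3 (within the scatter) in this assay, the first measured step at this position. Neither alkyl group, with 3 carbon atoms in one case and 1 in the other, gives a maximal response above that of the other here, so this pair does not show that the position affects the response. Going by these compounds, whether a longer chain or an aminoethyl group on that nitrogen would give a measurable response in this assay remains open. No supporting measurement bears on this result.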